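The source may report more compounds than this note shows. Statements on the series, on what has been measured and on what is new or still open speak of the compounds shown alone.

In a functional assay on MCF7 cells (Homo sapiens) for antiproliferative activity, read by MTT assay, with a stated time of 48 h (on this read-out lower numbers stand for stronger inhibition and higher numbers for weaker inhibition), compound 3 `COc1ccc(C(=O)/C=C/c2cccc(Br)c2Oc2c([N+](=O)[O-])cc(C(F)(F)F)cc2[N+](=O)[O-])cc1` gives 2.32 ug/mL. That places it level with compound 2 `COc1ccc(C(=O)/C=C/c2cc(Cl)cc(Cl)c2Oc2c([N+](=O)[O-])cc(C(F)(F)F)cc2[N+](=O)[O-])cc1`, which gives 2.69 ug/mL, a gap that lies within the usual scatter of repeated measurements. Compound 1 `Cc1ccc(C(=O)/C=C/c2cccc(Cl)c2Oc2c([N+](=O)[O-])cc(C(F)(F)F)cc2[N+](=O)[O-])cc1` stands well apart at 0.03 ug/mL, a far lower number and clearly beyond that scatter.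

Compound 4 `COc1ccc(C(=O)/C=C/c2cccc(Cl)c2Oc2c([N+](=O)[O-])cc(C(F)(F)F)cc2[N+](=O)[O-])cc1` differs from compound 3 in a single place: chloro in place of bromo on an aromatic carbon. In words, this is chloro in place of bromo on an aromatic carbon. No measured pair among these compounds shows this swap on its own, so the expectation has to rest on indirect evidence. Compound 2 also carries chloro and gives 2.69 ug/mL, close to compound 3 at 2.32 ug/mL, which suggests that a number of similar size is a reasonable expectation in this assay. The expected step of a 1.2-fold lower number from compound 3 to compound 4 (0.06 log units; within the scatter) is small, and no change beyond the scatter is expected in either direction. Compound 1 at 0.03 ug/mL shows how low the numbers can go among these compounds, so the expected range is left wider on the low side. The estimated value for compound 4 is 2 ug/mL, with an expected range from 0.4 ug/mL to 5 ug/mL.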

Compound 4, half-maximal inhibitory concentration: 1.83 ug/mL
Estimate against measurement, compound 4: 1.1-fold (0.04 log units) above; the range from low to high includes it.
By their numbers in this assay, from the lowest: compound 1; then compounds 4, 3 and 2 (each within the scatter of the next).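

In this assay, among these compounds, the step of a 1.3-fold lower number from compound 3 to compound 4 (0.10 log units; within the scatter) is the first direct reading of chloro in place of bromo on this aromatic carbon, and it stays within the usual scatter, so at this position and the two halogens cannot be told apart. The step of a 1.5-fold lower number from compound 2 to compound 4 (0.17 log units; within the scatter) adds a second reading, hydrogen in place of chloro on an aromatic carbon, and it also stays within the scatter, so that chloro shows no measurable effect here. By contrast, the step of a 61-fold higher number from compound 1 to compound 4 (1.79 log units; beyond the scatter) is large and lies well beyond the scatter, which shows that methoxy in place of methyl on an aromatic carbon, a change far from the halogens, is the one single change among these compounds that moves the number strongly.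

Nothing measured alongside these numbers explains why the halogen steps are small or the methoxy step is large. Still open, going by these compounds, is whether a much different group at the halogen position, such as an amine or a hydroxyl, would stay within the scatter, and whether the low number of compound 1 would survive bromo in place of its chloro.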